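A few compounds are considered here, and "the series" means these few. Any claim that something is new, unique, unknown or untested is made for them only; others in the source may bear on it.

Among the measured compounds shown here, in an ADME assay on MT4 cells (Homo sapiens) for cytotoxicity, read by MTT assay (on this read-out lower numbers stand for higher toxicity in this test and higher numbers for lower toxicity in this test), compound 1 `Cc1cc(C)cc(S(=O)(=O)c2c(C(=O)NC(C)c3cccc(O)c3)[nH]c3ccc(Cl)cc23)c1` gives 16000 nM and compound 2 `COc1cc(CNC(=O)c2[nH]c3ccc(Cl)cc3c2S(=O)(=O)c2cc(C)cc(C)c2)ccc1O` gives 28700 nM, so compound 2 stands within the scatter of the only other measured compound. For the measured compounds named here, the one measured step, a 1.8-fold higher number from compound 1 to compound 2 (0.25 log units; within the scatter), exchanges one group on the amide-type nitrogen for another and leaves the shared core unchanged. Compound 3 `Cc1cc(C)cc(S(=O)(=O)c2c(C(=O)NCC(=O)NCc3cccc(O)c3)[nH]c3ccc(Cl)cc23)c1` differs from compound 2 by (3-hydroxybenzyl)carbamoyl in place of 4-hydroxy-3-methoxyphenyl on a saturated chain carbon bound to an amide-type nitrogen, with (3-hydroxybenzyl)carbamoyl in place of 4-hydroxy-3-methoxyphenyl on a saturated chain carbon bound to an amide-type nitrogen. Going by the values given here, this change also leaves the shared core unchanged, but no measured compound carries this group, so the single step above is only a loose guide. No shift beyond the scatter is therefore expected. The expected change, a 1.3-fold lower number from compound 2 to compound 3 (0.12 log units; within the scatter), is estimated to stay within the scatter. For compound 3 the estimate is 22000 nM, with an expected range of 8000 nM to 60000 nM.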

Compound 3, half-maximal cytotoxic concentration: > 47500 nM
Compound 3 was reported as a limit (the forecaster's own chance of this, stated with the estimate: 15%); middle value at least 2.1-fold (0.33 log units) from the limit.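

Compound 3 is reported only as a limit in this assay: the limit of > 47500 nM in this assay, at which 1 of the 3 values shown sits. Even so, the group of compound 3 on the amide-type nitrogen gives the first step shown here that is beyond the scatter, an at least 2.9-fold higher number from compound 1 to compound 3 (0.47 log units; beyond the scatter). Measured against compound 2, (3-hydroxybenzyl)carbamoyl in place of 4-hydroxy-3-methoxyphenyl on a saturated chain carbon bound to an amide-type nitrogen gives an at least 1.6-fold higher number from compound 2 to compound 3 (0.21 log units; that floor lies within the scatter), so the floor of this step does not separate the two compounds.

The compounds shown leave open the actual number for compound 3 and which part of its larger group goes with the step from compound 1. They also do not tell how an amine, a carboxylic acid or a longer chain in place of (3-hydroxybenzyl)carbamoyl would read in this assay.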